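A Trifluoromethoxy Swap on a Shared Core

A few compounds are considered here, and "the series" means these few. Any claim that something is new, unique, unknown or untested is made for them only; others in the source may bear on it.

Compound 1, `Oc1ccccc1-c1cc(-c2cccc(C(F)(F)F)c2)cc(-c2ccccc2O)n1`: in a functional assay on DU-145 cells (Homo sapiens) for inhibition (a lower number here means a stronger inhibitor, a higher number a weaker inhibitor), compound 1 gives only a limit, > 50000 nM.
Compound 2, `Oc1ccccc1-c1cc(-c2ccc(C(F)(F)F)cc2)cc(-c2ccccc2O)n1`: compound 2 also gives only a limit, > 50000 nM.
Compound 3, `Oc1ccccc1-c1cc(-c2cccc(OC(F)(F)F)c2)cc(-c2ccccc2O)n1`: compound 3 gives 7470 nM.

Compounds 1 and 2 differ as 4-(trifluoromethyl)phenyl in place of 3-(trifluoromethyl)phenyl on an aromatic carbon; their values show a step that the two limits leave unreadable from compound 1 to compound 2, since both sit at the limit of > 50000 nM in this assay, at which 2 of the 3 values shown sit. Going by these compounds, from compound 1 to compound 3 the change is trifluoromethoxy in place of trifluoromethyl on an aromatic carbon, and it brings an at least 6.6-fold lower number from compound 1 to compound 3 (0.82 log units; beyond the scatter), though with the first value a limit the true size stays open.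

Compound 4, `Oc1ccccc1-c1cc(-c2ccc(OC(F)(F)F)cc2)cc(-c2ccccc2O)n1`, is not yet measured. It differs from compound 2 as trifluoromethoxy in place of trifluoromethyl on an aromatic carbon. This is the same kind of change as from compound 1 to compound 3, but the place differs: there the entering group sits meta to a large group, here para to a large group. Compound 2 rests at a limit, so the step can only be guessed; an expected step of an at least 4.1-fold lower number from compound 2 to compound 4 (0.61 log units; beyond the scatter) would mirror an at least 6.6-fold lower number from compound 1 to compound 3 (0.82 log units; beyond the scatter). Compound 4 is thus estimated at 12000 nM in this assay, between 3000 nM and 50000 nM, with a fair chance that only a limit is reported.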

Compound 4, half-maximal inhibitory concentration: 20300 nM
Estimate against measurement, compound 4: 1.7-fold (0.23 log units) below; the range from low to high includes it.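

In this assay, trifluoromethoxy in place of trifluoromethyl on the core of compound 2 brings an at least 2.4-fold lower number from compound 2 to compound 4 (0.39 log units; beyond the scatter). The number therefore falls with this change in both pairs shown, with the entering group para to a large group in this one, so the direction carries over between these two cores, and the two steps compare as follows: the same change on two cores in this assay, an at least 6.6-fold lower number (0.82 log units; beyond the scatter) from compound 1 to compound 3 and an at least 2.4-fold lower number (0.39 log units; beyond the scatter) from compound 2 to compound 4; the limit leaves it open whether they differ This does not show how large the effect really is on either core, or that it is equal on both, as compound 1 and compound 2 each give only a limit: the limit of > 50000 nM in this assay, at which 2 of the 4 values shown sit.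

The compounds shown leave open whether a simple methoxy group, a nitrile or an amine in the same place would also give a lower number than trifluoromethyl does. They also leave open whether the change would hold on a core in which the two hydroxyl groups of the shared core are replaced, for instance by methoxy groups, since every pair here keeps them.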